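This account rests on a few compounds, and the source may have more. Where it says the series, first, only, none or still open, it means among the compounds named here.

Working notes on the series in a functional assay on cells for antagonist activity at Free fatty acid receptor 1 (Homo sapiens), read by TR-FRET and inositol phosphate accumulation, with a stated time of 2 h; on this read-out lower numbers stand for stronger inhibition and higher numbers for weaker inhibition.

Compound 1 `Cc1cc(COc2cccc(F)c2)nc(-c2ccccn2)n1` gives 794 nM. Compound 2 `Cc1cc(COc2cccc(F)c2F)nc(-c2ccccn2)n1`, which carries one more fluoro on the aromatic carbon, gives 398 nM. Within the data shown here, the step of a 2.0-fold lower number from compound 1 to compound 2 (0.30 log units; within the scatter) is the only measured step so far, and it stays within the scatter, so compound 2 stands alongside compound 1 with no separation that can be read as real.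

Compound 3 `Cc1cc(COc2cc(F)cc(F)c2F)nc(-c2ccccn2)n1` has not yet been measured. Compound 3 differs from compound 2 by fluoro in place of hydrogen on an aromatic carbon. Among the measured compounds shown here, the one step that bears on this change is the earlier fluoro-for-hydrogen step from compound 1 to compound 2, which moved the number by a 2.0-fold lower number from compound 1 to compound 2 (0.30 log units; within the scatter) only. On that basis a change in this assay of about a 1.3-fold lower number from compound 2 to compound 3 (0.12 log units; within the scatter) is expected, small and not clearly beyond the scatter. Compound 3 is therefore estimated at 300 nM, with a range from 120 nM to 750 nM.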

Compound 3, half-maximal inhibitory concentration in the Free fatty acid receptor 1 assay: 501 nM
For compound 3 the middle estimate is 1.7-fold (0.22 log units) below the measured one, and the stated range covers the measured number.
By their numbers in the Free fatty acid receptor 1 assay, from the lowest: compounds 2, 3 and 1 (each within the scatter of the next).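

In the Free fatty acid receptor 1 assay, the new fluoro, which sits para to a fluoro group and meta to a large group, gives a 1.3-fold higher number from compound 2 to compound 3 (0.10 log units; within the scatter), so a further fluoro here opens no separation that can be read as real, and the ring carrying the fluoro groups accepts this replacement without a clear shift. In a physicochemical assay for lipophilicity, at pH 7.4 (on this read-out lower numbers stand for lower lipophilicity and higher numbers for higher lipophilicity), compound 2 gives 3.2 and compound 3 gives 3.4. In the physicochemical assay, the same change gives a number 0.20 log units higher from compound 2 to compound 3 (within the scatter), so neither read-out separates the two compounds. Nothing at hand bears on why the numbers behave this way.

As far as these compounds go, whether a group other than fluoro at this position, such as an amine, a carboxylic acid or a methoxy group, would move the number beyond the scatter stays open. Also open, from the compounds shown here alone, is whether any replacement on this ring can do so in the Free fatty acid receptor 1 assay at all.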